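The source may report more compounds than this note shows. Statements on the series, on what has been measured and on what is new or still open speak of the compounds shown alone.

Compound 3 `COc1cc2nc(OC3CCN(C(=O)OC(C)(C)C)CC3)nc(Nc3ccc(S(C)(=O)=O)cc3F)c2cc1OC` is the subject of this step. In a functional assay on HEK293 cells for agonist activity at Glucose-dependent insulinotropic receptor (Homo sapiens), read by cAMP accumulation, with a stated time of 60 min (a higher number here means a larger maximal response, a lower number a smaller maximal response), compound 3 gives 19.6%, the lowest of the three values measured. The nearest is compound 1 `COc1cc2nc(Nc3ccc(S(C)(=O)=O)cc3)nc(N3CCC4CCC(C3)N4Cc3ccccc3)c2cc1OC`, which in this assay gives 32.8%, a gap beyond the usual scatter; the furthest is compound 2 `COc1cc2nc(N3CCC4CCC(C3)N4Cc3ccccc3)nc(Nc3ccc(S(C)(=O)=O)cc3F)c2cc1OC`, which in this assay gives 44.3%, also beyond the scatter. Among the measured compounds shown here, compounds 1 and 2 differ from each other and from compound 3 in more than one place, so no single step links them.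

Compound 4 `COc1cc2nc(OC3CCN(C(=O)OC(C)(C)C)CC3)nc(Nc3ccc(S(C)(=O)=O)cc3)c2cc1OC` differs from compound 3 in one place: hydrogen in place of fluoro on an aromatic carbon. For the measured compounds named here, no pair of measured compounds shows this change alone, so its size is not known here. Compound 1 carries hydrogen at that aromatic carbon and compound 2 carries fluoro, but their other differences keep their values from settling the question. The change from compound 3 to compound 4 is expected to be small, at most slightly downward, giving a number 2.6 percentage points lower from compound 3 to compound 4 (within the scatter). Compound 4 is therefore estimated at 17%, with a range from 8% to 30%.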

Compound 4, largest response reached (Emax), in percent of the reference or control that the assay uses: 17.9%
Estimate against measurement, compound 4: 0.9 percentage points below, and the stated range covers the measured number.
By their numbers in this assay, from the lowest: compounds 4 and 3 (each within the scatter of the next); then compound 1; then compound 2.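

In this assay, among the compounds shown here, putting hydrogen in place of fluoro on the aromatic carbon ortho to a large group and meta to a methylsulfonyl group gives a number 1.7 percentage points lower from compound 3 to compound 4 (within the scatter), the first change in this set that can be read alone. With everything else in compound 3 held fixed, the response therefore does not separate fluoro from hydrogen at this position. This single step says nothing about the other differences that separate compound 1 and compound 2 from these two compounds, and no measurement shown here explains the small size of the step.

From the compounds shown here alone, whether chloro, methoxy or a nitrile on that same carbon would move the maximal response remains open. Also open, going by these compounds, is whether the exchange of fluoro for hydrogen would stay this small on the different substituent carried by compound 1 and compound 2.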